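A few compounds are considered here, and "the series" means these few. Any claim that something is new, unique, unknown or untested is made for them only; others in the source may bear on it.

Compound 1 `O=C(O)c1cn(-c2ccccc2)c2ccc(Cc3cccc(Cl)c3F)c(O)c2c1=O` gives 388000 nM in an ADME assay on C8166 cells (Homo sapiens) for cytotoxicity, read by MTT assay; on this read-out lower numbers stand for higher toxicity in this test and higher numbers for lower toxicity in this test.
Compound 2 `Cc1ccc(-n2cc(C(=O)O)c(=O)c3c(O)c(Cc4cccc(Cl)c4F)ccc32)cc1C` gives 316000 nM in this assay.

Both numbers are high, so neither compound harms the cells until large amounts are present. For the measured compounds named here, compound 2 holds the lowest of the two numbers, but its only neighbour, compound 1, sits within the scatter of it, so the two cannot be told apart. Going by the values given here, the one measured step, a 1.2-fold lower number from compound 1 to compound 2 (0.09 log units; within the scatter), shows that exchanging one aromatic group for another on the aromatic nitrogen left the read-out essentially where it was.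

Compound 3 `O=C(O)c1cn(Cc2ccccc2)c2ccc(Cc3cccc(Cl)c3F)c(O)c2c1=O` has not been measured. Its difference from compound 2 is benzyl in place of 3,4-dimethylphenyl on an aromatic nitrogen: the group on the aromatic nitrogen is exchanged once more, and the entering benzyl is of almost the same size as the group that leaves. Among the compounds with values here, no measured step involves a benzyl group, so the only guide is the step from compound 1 to compound 2, which stayed within the scatter. On that basis the change is expected to produce no step beyond the scatter, a 1.1-fold higher number from compound 2 to compound 3 (0.03 log units; within the scatter). Compound 3 is therefore estimated to give about 340000 nM, with a range from 150000 nM to 750000 nM.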

Compound 3, half-maximal cytotoxic concentration: 20300 nM
Compound 3: the middle estimate sits 17-fold (1.22 log units) above what was measured; the whole stated range lies above it.
By their numbers in this assay, from the lowest: compound 3; then compounds 2 and 1 (each within the scatter of the next).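

In this assay, the group on the aromatic nitrogen turns out to matter: benzyl in place of 3,4-dimethylphenyl gives a 16-fold lower number from compound 2 to compound 3 (1.19 log units; beyond the scatter), and benzyl in place of phenyl gives a 19-fold lower number from compound 1 to compound 3 (1.28 log units; beyond the scatter), so toxicity in this test is clearly higher with benzyl. The earlier pair suggested that this position tolerates exchange, but that pair only compared rings sitting directly on the nitrogen, whereas the ring of benzyl reaches the nitrogen through a carbon link, and a group of almost the same size can therefore still give a very different number. No measurement available here explains why this exchange has such a large effect.

For the compounds shown here, with only one compound carrying such a link, these compounds cannot show whether the link itself goes with the lower number or whether something particular to benzyl does. Also open, as far as these compounds go, is where a longer chain such as phenethyl, a benzyl ring bearing methyl groups, or a plain ethyl group with no ring at all would fall on this read-out.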